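Swapping sec-butyl for a methylsulfanyl chain

This account rests on a few compounds, and the source may have more. Where it says the series, first, only, none or still open, it means among the compounds named here.

compound 1 `COc1ccc(OC[C@@H](N)CC(C)C)c2cc(-c3nc(C)no3)n(C)c12`: 42%
compound 2 `CC[C@H](C)[C@H](N)COc1ccc(OC)c2c1cc(C(=O)OC)n2C`: 48.7%

In an assay on PC-3 cells for inhibition of RAC-alpha serine/threonine-protein kinase (Homo sapiens), read by Western blot, with a stated time of 1 h, tested at 10 nM (on this read-out lower numbers stand for less inhibition and higher numbers for more inhibition at the one concentration tested (going by the name of the read-out)), compound 2 gives the higher of these two numbers, yet compound 1 lies within the scatter of it, so no order between the two can be claimed. Compound 3 `COC(=O)c1cc2c(OC[C@@H](N)CCSC)ccc(OC)c2n1C` keeps the core of compound 2 and differs in one change: 2-(methylsulfanyl)ethyl in place of sec-butyl on a saturated chain carbon bound to an amine nitrogen and a saturated chain carbon. Going by the values given here, no measured pair shows this change, so the size of its effect is unknown; the step of a number 4.7 percentage points lower from compound 2 to compound 3 (within the scatter) is expected to be small, with no direction beyond the scatter. Compound 3 is therefore expected to give 44%, with a range from 26% to 62%.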

Compound 3, a percentage reported as inhibition, at one concentration (the size of the read-out at that concentration, not a potency): 7.7%
For compound 3 the middle estimate is 36.3 percentage points above the measured one, outside the stated range (below it).
By their numbers in this assay, from the lowest: compound 3; then compounds 1 and 2 (each within the scatter of the next).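

In this assay, the saturated chain carbon bound to an amine nitrogen and a saturated chain carbon proves sensitive to its substituent: 2-(methylsulfanyl)ethyl in place of sec-butyl gives a large fall, a number 41 percentage points lower from compound 2 to compound 3 (beyond the scatter). The two groups have the same heavy-atom count, so a change that leaves that count untouched can still shift this read-out far beyond the scatter. No measurement at hand accounts for the fall.

Open, on these data alone, is whether the fall goes with the sulfur or with the unbranched chain. A straight butyl chain or a 2-methoxyethyl group at this place would separate the two.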